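The compounds below may be only part of what the source reports. "The series", "measured", "known", "first", "only" and "open" are said of these compounds alone.

Measured in a functional assay, with a stated time of 20 min, tested at 2.5 mg/mL; a higher number here means a stronger effect of the compound at the concentration tested, a lower number a weaker effect:

Compound 1, `CC(C)[C@@H]1CC[C@@H](C)C[C@@]12N(C)C(=O)[C@@H]1[C@H]3C(=O)N(c4ccc(Cl)cc4)C(=O)[C@H]3ON12` — compound 1 gives 53.1%
Compound 2, `COc1ccc(N2C(=O)[C@H]3[C@H](ON4[C@@H]3C(=O)N(C)[C@@]43C[C@H](C)CC[C@H]3C(C)C)C2=O)cc1` — compound 2 gives 65.3%

Within the data shown here, compound 2 stands highest of the two numbers in this assay, its nearest neighbour being compound 1; the single measured step, a number 12.2 percentage points higher from compound 1 to compound 2 (beyond the scatter), is beyond the scatter and came with a methoxy in place of chloro on an aromatic carbon.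

Compound 3, `CC(C)[C@@H]1CC[C@@H](C)C[C@@]12N(C)C(=O)[C@@H]1[C@H]3C(=O)N(c4ccc5ccccc5c4)C(=O)[C@H]3ON12`, is not yet measured. It differs from compound 2 in one place: naphthalen-2-yl in place of 4-methoxyphenyl on an amide-type nitrogen in a ring. Among the measured compounds shown here, the one measured step only partly bears on this change, since it swapped a group on the same aromatic ring, whereas here the whole ring is replaced by naphthalen-2-yl. With no step of this kind in hand, no direction can be read off, and a change of either sign or none beyond the scatter is possible.

Compound 3 is therefore expected to give about 60% in this assay, within a wide range from 40% to 78%. This estimate means a step of a number 5.3 percentage points lower from compound 2 to compound 3 (within the scatter), expected to lie within the scatter.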

Compound 3, a percentage reported as activity, at one concentration (the size of the read-out at that concentration, not a potency): 39.6%
Beside the measured number, compound 3's estimate is 20.4 percentage points above it; measured number outside the range, below it.
By their numbers in this assay, from the lowest: compound 3; then compound 1; then compound 2.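

In this assay, the group on the amide-type nitrogen was until now varied only through a swap on its aromatic ring, and replacing that whole group also moves the read-out: naphthalen-2-yl in place of 4-methoxyphenyl gives a number 25.7 percentage points lower from compound 2 to compound 3 (beyond the scatter), and in place of 4-chlorophenyl it gives a number 13.5 percentage points lower from compound 1 to compound 3 (beyond the scatter). Both steps point the same way, so among these three compounds the two substituted phenyl groups stand above naphthalen-2-yl, and compound 3 has the lowest number, with no compound here going against this order. Nothing measured here bears on what lies behind this drop.

Three compounds cannot separate the effect of the second fused aromatic ring from the loss of the chloro or methoxy group, and a plain phenyl or a naphthalen-1-yl group on the same nitrogen would help to tell these apart. Going by these compounds, it also remains open how a non-aromatic group such as cyclohexyl, or a phenyl carrying an amine or a carboxylic acid, would fare in this assay.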